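A few compounds are considered here, and "the series" means these few. Any claim that something is new, unique, unknown or untested is made for them only; others in the source may bear on it.

Working notes on the hydroxamic acid series.

Two compounds carry a measurement in a physicochemical assay, read by HPLC, at 40 degrees C, tested at 0.1 mg/mL; on this read-out higher numbers stand for a more stable compound and lower numbers for a less stable compound. Compound 1 `Cc1cc(COc2ccc(S(=O)(=O)NC3(CC(=O)NO)CN(CCC(F)(F)F)C3)cc2)c2ccccc2n1` gives 88% in this assay. Compound 2 `Cc1cc(COc2ccc(S(=O)(=O)N(C)C3(C(=O)NO)CN(CCC(F)(F)F)C3)cc2)c2ccccc2n1` gives 98% in this assay. Compound 2 reads at the upper end of the two numbers, and compound 1 sits within the usual scatter of it, so the two readings are not told apart. Among the compounds with values here, compound 1 and compound 2 differ in more than one place, so no single step between them can be drawn.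

Compound 3 `Cc1cc(COc2ccc(S(=O)(=O)NC3(C(=O)NO)CN(CCC(F)(F)F)C3)cc2)c2ccccc2n1` is the next compound to be measured in this assay. Compound 3 differs from compound 2 by hydrogen in place of methyl on a sulfonamide nitrogen.

Within the data shown here, no step in this assay is known for a change of this kind, since compound 1 differs from compound 2 at more than one place. The expectation is therefore a step from compound 2 to compound 3 of a number 8 percentage points lower from compound 2 to compound 3 (within the scatter), a move not expected to reach beyond the scatter. The estimate for compound 3 in this assay is 90%, with a range from 78% to 100%.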

Compound 3, percent of the compound remaining: 58%
Estimate against measurement, compound 3: 32 percentage points above, outside the stated range (below it).
By their numbers in this assay, from the lowest: compound 3; then compounds 1 and 2 (each within the scatter of the next).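

In this assay, the sulfonamide nitrogen proves to be a position that counts: hydrogen in place of methyl there gives a number 40 percentage points lower from compound 2 to compound 3 (beyond the scatter), a large step that the earlier pair, differing in more than one place, could not show. The saturated ring carbon counts as well, since hydroxycarbamoyl in place of (hydroxycarbamoyl)methyl gives a number 30 percentage points lower from compound 1 to compound 3 (beyond the scatter), so each of the two changes, read singly from compound 3, is beyond the scatter, even though compound 1 and compound 2 themselves are not told apart. Nothing available bears on what lies behind either step.

On these data alone, both steps end at compound 3, so each change is known only against that one compound, and whether the two add up or overlap stays open, as a compound joining methyl on the sulfonamide nitrogen with (hydroxycarbamoyl)methyl on the saturated ring carbon would be needed to tell. Also open, as far as these compounds go, is whether ethyl or a longer chain on the sulfonamide nitrogen would read like methyl, and whether a longer chain than (hydroxycarbamoyl)methyl would hold the reading of compound 1.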